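The compounds below may be only part of what the source reports. "The series", "measured", "known", "first", "only" and "open" are said of these compounds alone.

Measured so far:
compound 1 `Cc1cc2[nH]nc(N)c2c(=O)[nH]1`, -3%
compound 2 `Nc1n[nH]c2cc(-c3cccnc3)[nH]c(=O)c12`, 7%
compound 3 `COc1ccc(-c2cc3[nH]nc(N)c3c(=O)[nH]2)cc1`, 21%

All three were run in an assay on isolated protein for inhibition of RAC-alpha serine/threonine-protein kinase (Homo sapiens), read by mobility shift assay, tested at 30 uM; on this read-out lower numbers stand for less inhibition and higher numbers for more inhibition at the one concentration tested (going by the name of the read-out). Compound 1 sits at the low end of the three numbers: compound 2 lies within the scatter of it, while compound 3 lies beyond the scatter, higher. Compound 3 thus stands apart from compound 1; compound 2 does not.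

Compound 4 `Nc1n[nH]c2cc(-c3cccs3)[nH]c(=O)c12` is not yet measured. Against compound 1 it shows (thiophen-2-yl in place of methyl on an aromatic carbon). For the measured compounds named here, no step between measured compounds that differ in one place is available, so the expectation rests on the two aryl-bearing compounds. Since compound 2 gives 7% and compound 3 gives 21%, a ring in this place appears to move the read-out upward by a small amount at most. For compound 4 a step of a number 13 percentage points higher from compound 1 to compound 4 (beyond the scatter) is expected, upward and close to the edge of the scatter. Compound 4 is estimated at 10%, with a range from -5% to 30%.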

Compound 4, a percentage reported as inhibition, at one concentration (the size of the read-out at that concentration, not a potency): 4%
Beside the measured number, compound 4's estimate is 6 percentage points above it; the range from low to high includes it.
By their numbers in this assay, from the lowest: compounds 1, 4 and 2 (each within the scatter of the next); then compound 3.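

In this assay thiophen-2-yl in place of methyl on an aromatic carbon gives a number 7 percentage points higher from compound 1 to compound 4 (within the scatter) and the two numbers cannot be told apart. For the compounds shown here, this is the first step that can be read at this position, and it shows that an aromatic ring here, next to the ring nitrogen, does not by itself separate a compound from the methyl compound. No measurement on hand offers a reason for this result.

On these data alone, it remains open what sets compound 3 at 21% apart, whether its ring alone or the methoxy group on that ring, and a plain phenyl at this place would bear on that question. Also open, as far as these compounds go, is how a non-aromatic group at this position would read, such as an aminomethyl group, a carboxylic acid or a longer alkyl chain.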